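The source may hold more compounds than are shown below. What is called first, only, known or untested is meant among the compounds shown, and "the series" means these compounds.

Measured compounds, with their results in a functional assay on A549 cells (Homo sapiens) for cytotoxicity, read by MTT assay, with a stated time of 48 h; on this read-out lower numbers stand for stronger inhibition and higher numbers for weaker inhibition:
- compound 1 `COc1c(OCCCN2CCNCC2)cc(O)c2c(=O)cc(-c3ccccc3)oc12`: 10100 nM
- compound 3 `COc1c(OCCCCNCc2ccccc2)cc(O)c2c(=O)cc(-c3ccccc3)oc12`: 4590 nM
- compound 2 `CCCCNCCCCOc1c(O)cc(O)c2c(=O)cc(-c3ccccc3)oc12`: "not determined" (no result reported)

Compound 2 therefore stands nowhere on the numbers shown; it shares the hydroxy-bearing core with the unmeasured compound 4 `CN1CCN(CCCCOc2c(O)cc(O)c3c(=O)cc(-c4ccccc4)oc23)CC1` but offers no value of its own to build on. Compound 4 differs from compound 2 in one place: 4-methylpiperazin-1-yl in place of butylamino on a saturated chain carbon, four bonds along the chain from an oxygen on an aromatic ring.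

Within the data shown here, the only measured step that speaks to an amine change at the chain end is the one from compound 1 to compound 3, where a 2.2-fold lower number from compound 1 to compound 3 (0.34 log units; beyond the scatter). That step replaced a piperazine ring with an open benzylamine chain; the change from compound 2 to compound 4 runs the other way, an open butylamine chain giving way to a 4-methylpiperazin-1-yl ring, on a longer chain and a different core. Taken together, these steps suggest a modest step in this assay, more likely toward a higher number, though nothing beyond the scatter can be relied upon. Compound 4 is expected to give about 10000 nM, within a range of 3500 nM to 30000 nM.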

Compound 4, half-maximal inhibitory concentration: > 100000 nM
Compound 4 was reported as a limit; the forecaster's own chance of this, stated with the estimate: 15%; middle value at least 10-fold (1.00 log units) away from the limit.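

No new step can be read between compound 2 and compound 4: compound 2 carries no number in this assay. Compound 4 is reported only as a limit, > 100000 nM. The compounds shown leave open how butylamino and 4-methylpiperazin-1-yl compare on the shared core.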